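Working notes: compound 2 to compound 4 in the series

The compounds below may be only part of what the source reports. "The series", "measured", "known", "first", "only" and "open" are said of these compounds alone.

Compounds measured so far in an assay on HEK293 cells for positive allosteric modulation of metabotropic glutamate receptor 3 (Rattus norvegicus), read by thallium flux, with a stated time of 2.5 min; a higher number here means a larger maximal response, a lower number a smaller maximal response:
compound 1 `Cc1c(OCCCCOc2ccc(C(=O)O)cc2Cl)ccc(C(=O)CC2CCCC2)c1O`: 27.4%
compound 2 `COc1ccc(C(=O)O)cc1OCCCCOc1ccc(C(=O)CC2CCCC2)c(O)c1C`: 67.6%
compound 3 `Cc1cc(C(=O)O)ccc1OCCCCOc1ccc(C(=O)CC2CCCC2)c(O)c1C`: 28.4%

Compound 2 holds the highest of the three numbers in this assay; the nearest is compound 3, with a step of a number 39.2 percentage points lower from compound 2 to compound 3 (beyond the scatter), and the furthest is compound 1, as the step of a number 40.2 percentage points higher from compound 1 to compound 2 (beyond the scatter) shows. The step of a number 1 percentage points higher from compound 1 to compound 3 (within the scatter) lies within the scatter.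

Compound 4 `CCC(=O)c1ccc(OCCCCOc2cc(C(=O)O)ccc2OC)c(C)c1O` is not yet measured. It differs from compound 2 in one place: methyl in place of cyclopentyl on a saturated chain carbon bound to a carbonyl carbon. Within the data shown here, none of the three measured steps touches this part of the molecule; all of them change the aryl group on the other oxygen on a saturated carbon, so no measured step bears on the change from compound 2 to compound 4. Without a bearing step, the expectation for compound 4 is wide: a step of a number 17.6 percentage points lower from compound 2 to compound 4 (beyond the scatter) is estimated, of uncertain direction, with a lean toward a smaller maximal response. Compound 4 is expected to give 50% in this assay, with a range from 25% to 75%.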

Compound 4, largest response reached (reported as percent of maximum), in percent of the reference or control that the assay uses: 62.5%
Compound 4: middle estimate off by 12.5 percentage points, on the low side, within the range that was stated.
By their numbers in this assay, from the lowest: compounds 1 and 3 (each within the scatter of the next); then compounds 4 and 2 (each within the scatter of the next).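

In this assay the change of cyclopentyl to methyl on a saturated chain carbon bound to a carbonyl carbon gives a step of a number 5.1 percentage points lower from compound 2 to compound 4 (within the scatter) and so separates the two compounds by no more than the usual scatter. Among these compounds, the one five-membered non-aromatic ring of carbon only can therefore go, with cyclopentylmethyl cut back to ethyl, and the maximal response stays level for this pair, whereas the earlier steps, all in the aryl group on the other oxygen, included large ones. No supporting data explain this result.

On these data alone, only compound 2 and compound 4 bear on this position, and both carry the 5-carboxy-2-methoxyphenyl group, so the outcome with 4-carboxy-2-chlorophenyl remains open. Also open, as far as these compounds go, is whether a phenyl ring, an amine or a longer chain at this place would leave the response level.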